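Removal of a ring methyl in a small growth-inhibition series

A few compounds are considered here, and "the series" means these few. Any claim that something is new, unique, unknown or untested is made for them only; others in the source may bear on it.

All three measured compounds were tested in a functional assay on HeLa cells (Homo sapiens) for cytotoxicity, read by MTT assay, with a stated time of 72 h, tested at 3 uM; on this read-out higher numbers stand for more inhibition of growth at the one concentration tested and lower numbers for less inhibition of growth.

compound 1, `N/C(=N\NC(=S)N1CCCCCC1)c1ccccn1`: 36.6%
compound 2, `Cc1cccc(/C(N)=N/NC(=S)N2CCCCCC2)n1`: 63.6%
compound 3, `Cc1cccc(/C(N)=N/NC(=S)N2CCCC2)n1`: 56.8%

Compound 2 and compound 1 differ in one place: hydrogen in place of methyl on an aromatic carbon. In this assay the change gives a number 27 percentage points lower from compound 2 to compound 1 (beyond the scatter). Compound 3 and compound 2 both carry the ring methyl but sit on different cores; the difference between the two cores is not broken down here. In this assay compound 3 gives 56.8% and compound 2 gives 63.6%, the two lying within the scatter of each other, whereas the gap from compound 3 down to compound 1 is beyond the scatter.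

Compound 4, `N/C(=N\NC(=S)N1CCCC1)c1ccccn1`, has not yet been measured. It stands to compound 3 as compound 1 stands to compound 2: hydrogen in place of methyl on an aromatic carbon. The place is described in the same words for both pairs, so this is the same change, occurring twice in the set. Because a number 27 percentage points lower from compound 2 to compound 1 (beyond the scatter) was seen on the core of compound 2, a step of similar size and direction is expected for compound 4 on the core of compound 3, namely a number 24.8 percentage points lower from compound 3 to compound 4 (beyond the scatter), though this rests on a single earlier pair and on two values that lie within the scatter of each other. Compound 4 is therefore estimated at 32% in this assay, with a range from 15% to 50%.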

Compound 4, percent growth inhibition at one concentration: 38.5%
Compound 4: the middle estimate sits 6.5 percentage points below what was measured; the measured number falls inside the stated range.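

In this assay the replacement of methyl by hydrogen on an aromatic carbon, next to the ring nitrogen, gives a number 18.3 percentage points lower from compound 3 to compound 4 (beyond the scatter) on the second core, so the drop seen on the first core recurs. The two steps agree in direction, and their sizes cannot be told apart in this read-out: the same change on two cores in this assay, a number 27 percentage points lower (beyond the scatter) from compound 2 to compound 1 and a number 18.3 percentage points lower (beyond the scatter) from compound 3 to compound 4, 8.7 percentage points apart, within the scatter of two such steps. For the compounds shown here, this supports carrying the change between these two cores, but it rests on only two matched pairs at one concentration in one cell line, so it does not establish that the step would hold on any other core, and it gives no reason why the methyl matters.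

The compounds shown leave open whether the gain tied to methyl is specific to that group, since ethyl, methoxy, chlorine and an amine at the same place would each test a different replacement on these cores. They also leave open how the pairs would compare across a full concentration range, and whether the methyl and hydrogen compounds would keep this relationship in cell lines other than the one used here.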